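Changing the aromatic arm of compound 2

This account rests on a few compounds, and the source may have more. Where it says the series, first, only, none or still open, it means among the compounds named here.

Compound 1 `COc1ccccc1-c1ccc(CNc2nc(NC3CCC(N)CC3)nc3c2ncn3C2CCCC2)cc1`: 430 nM
Compound 2 `NC1CCC(Nc2nc(NCc3ccc(-c4ccco4)cc3)c3ncn(C4CCCC4)c3n2)CC1`: 129 nM
Compound 3 `CC(C)(O)CNc1nc(NCc2ccc(-c3ccco3)cc2)c2ncn(C3CCCC3)c2n1`: 16700 nM

In a functional assay on HCT-116 cells (Homo sapiens) for inhibition, with a stated time of 72 h (on this read-out lower numbers stand for stronger inhibition and higher numbers for weaker inhibition), compound 2 gives the lowest of the three numbers, 129 nM. Compound 4 `NC1CCC(Nc2nc(NCc3ccc(-c4ccccc4)nc3)c3ncn(C4CCCC4)c3n2)CC1` differs from compound 2 on a saturated chain carbon bound to a nitrogen on an aromatic ring: 6-phenylpyridin-3-yl in place of 4-(furan-2-yl)phenyl on a saturated chain carbon bound to a nitrogen on an aromatic ring. The nearest guide is a swap within this same arm, a 3.3-fold lower number from compound 1 to compound 2 (0.52 log units; beyond the scatter), a modest step. The large step, a 130-fold higher number from compound 2 to compound 3 (2.11 log units; beyond the scatter), came from replacing 4-aminocyclohexyl, which compound 4 keeps, so it bears little on this change. A small step towards a higher number is therefore expected, possibly no more than scatter: a 1.6-fold higher number from compound 2 to compound 4 (0.19 log units; within the scatter). Compound 4 is estimated at 200 nM, with an expected range of 55 nM to 700 nM.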

Compound 4, half-maximal inhibitory concentration: 563 nM
Estimate against measurement, compound 4: 2.8-fold (0.45 log units) below; measured number inside the range.
By their numbers in this assay, from the lowest: compound 2; then compounds 1 and 4 (each within the scatter of the next); then compound 3.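

In this assay, exchanging 4-(furan-2-yl)phenyl for 6-phenylpyridin-3-yl gives a 4.4-fold higher number from compound 2 to compound 4 (0.64 log units; beyond the scatter), so this arm still moves the number beyond the scatter when the hydrogen-bond acceptor count stays the same. Compound 2 now has the lowest number among the arms carrying 4-aminocyclohexyl, while compound 1 and compound 4 lie within the scatter of each other. No available evidence explains this step. Both aromatic rings change together here, and the compounds shown do not separate their contributions. From the compounds shown here alone, how a thiophen-2-yl group on the same phenyl would read remains open.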